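A few compounds are considered here, and "the series" means these few. Any claim that something is new, unique, unknown or untested is made for them only; others in the source may bear on it.

Three ureas built on one shared core have been measured in an assay on isolated protein for inhibition of STE20-like serine/threonine-protein kinase (Homo sapiens), read by thermal shift assay, tested at 10 uM; on this read-out lower numbers stand for weaker stabilisation of the target and higher numbers for stronger stabilisation of the target against heat. Compound 1 `Cc1ccccc1NC(=O)Nc1cc(C(C)(C)C)nn1-c1ccccc1` gives 7.1 degrees C, compound 2 `Cc1ccc(NC(=O)Nc2cc(C(C)(C)C)nn2-c2ccccc2)cc1` gives 4.6 degrees C, and compound 3 `CC(C)(C)c1cc(NC(=O)Nc2cc(F)cc(F)c2)n(-c2ccccc2)n1` gives 3 degrees C, the lowest of the three, since the step of a number 2.5 degrees C lower from compound 1 to compound 2 (beyond the scatter), the step of a number 1.6 degrees C lower from compound 2 to compound 3 (beyond the scatter) and the step of a number 4.1 degrees C lower from compound 1 to compound 3 (beyond the scatter) all lie beyond the scatter. Compound 4 `Cc1ccc(-n2nc(C(C)(C)C)cc2NC(=O)Nc2cc(F)cc(F)c2)cc1` differs from compound 3 by methyl in place of hydrogen on an aromatic carbon. This change sits on a ring that none of the three measured steps touched; those steps all varied the ring on the urea nitrogen, so they offer no direct guide here. The expected step of no change at the digits printed from compound 3 to compound 4 (within the scatter) is therefore none beyond the scatter. Compound 4 is estimated at 3 degrees C, within 1.5 degrees C to 4.5 degrees C.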

Compound 4, shift of the target's melting temperature: 2.8 degrees C
For compound 4 the middle estimate is 0.20 degrees C above the measured one; the measured number falls inside the stated range.
By their numbers in this assay, from the lowest: compounds 4 and 3 (each within the scatter of the next); then compound 2; then compound 1.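

Going from phenyl to 4-methylphenyl, with the methyl para to a large group, gives a number 0.20 degrees C lower from compound 3 to compound 4 (within the scatter) in this assay, so this added methyl leaves no difference that can be told from scatter. Within the data shown here, this is the first reading at this ring, as the earlier steps all changed the group on the amide-type nitrogen. Nothing shown gives a reason for this result.

As far as these compounds go, whether an amine, a carboxylic acid or a longer chain such as propyl would behave the same at this place stays open. So does whether the methyl would have the same small effect alongside the 2-methylphenyl group of compound 1.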